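This account rests on a few compounds, and the source may have more. Where it says the series, first, only, none or still open, it means among the compounds named here.

Measured so far in a functional assay on J774 cells (Mus musculus) for cytotoxicity; on this read-out higher numbers stand for weaker inhibition and lower numbers for stronger inhibition:
- compound 1 `CCCN(CCC)c1c([N+](=O)[O-])cc(S(=O)(=O)Nc2cccc(OC)c2)cc1[N+](=O)[O-]`: 25000 nM
- compound 2 `CCCN(CCC)c1c([N+](=O)[O-])cc(S(=O)(=O)N(C)c2ccccc2)cc1[N+](=O)[O-]`: 11000 nM

Within the data shown here, of the two numbers, compound 2 holds the lower, at 11000 nM, and compound 1 is its only neighbour. The next structure is compound 3 `CCCN(CCC)c1c([N+](=O)[O-])cc(S(=O)(=O)N(c2ccccc2)c2ccccc2)cc1[N+](=O)[O-]`, and the change is phenyl in place of methyl on a sulfonamide nitrogen.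

Among the measured compounds shown here, only one measured step bears on this. It is a 2.3-fold lower number from compound 1 to compound 2 (0.36 log units; beyond the scatter), a modest step beyond the scatter, with methyl(phenyl)amino in place of (3-methoxyphenyl)amino on a sulfonyl sulfur. For the measured compounds named here, that exchange also alters the sulfonamide nitrogen, but it is not the same exchange, and no measured pair swaps methyl for phenyl at this place. It is therefore a weak guide. In this assay, a step no larger than that one is expected, leaning toward a lower number, and it may well stay within the scatter.

The expected step is a 1.6-fold lower number from compound 2 to compound 3 (0.20 log units; within the scatter).

For compound 3 the estimated value is 7000 nM, with an expected range from 2500 nM to 18000 nM.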

Compound 3, half-maximal inhibitory concentration: > 100000 nM
Compound 3: a limit, no number; the forecaster's own chance of this, stated with the estimate: 10%; middle value at least 14-fold (1.15 log units) from the limit.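

In this assay compound 3 gives > 100000 nM, which is a limit of the assay and not a number. Phenyl in place of methyl on a sulfonamide nitrogen gives an at least 9.0-fold higher number from compound 2 to compound 3 (0.95 log units; beyond the scatter), so this place does not tolerate every carbon group equally, and the step runs in the opposite direction to a 2.3-fold lower number from compound 1 to compound 2 (0.36 log units; beyond the scatter), which was a different exchange on the same nitrogen. Compound 3 is the only one of the series resting on that limit, so the step can be read for its direction and its lower bound only: the limit of > 100000 nM in this assay, at which 1 of the 3 values shown sits.

The compounds shown leave open where between methyl and phenyl the number begins to climb, for instance with an ethyl group, a longer chain or a benzyl group on this nitrogen. They also leave open whether a nitrogen carrying a second ring with an amine or a carboxylic acid attached would behave like compound 3 or return towards compound 2 at 11000 nM.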